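Nitro to amino exchange on two different cores

The source may hold more compounds than are shown below. What is called first, only, known or untested is meant among the compounds shown, and "the series" means these compounds.

Compound 1 `COc1ccc(NS(=O)(=O)/C=C/c2c(F)c(F)c(F)c(F)c2F)cc1[N+](=O)[O-]` and compound 2 `COc1ccc(NS(=O)(=O)/C=C/c2c(F)c(F)c(F)c(F)c2F)cc1N` share one core; compound 3 `COc1cc(OC)c(/C=C/S(=O)(=O)Nc2ccc(OC)c([N+](=O)[O-])c2)c(OC)c1` and the not yet measured compound 4 `COc1cc(OC)c(/C=C/S(=O)(=O)Nc2ccc(OC)c(N)c2)c(OC)c1` share another. The difference between the two cores is not broken down here.

In a functional assay on DU-145 cells (Homo sapiens) for cytotoxicity, read by trypan blue exclusion, with a stated time of 96 h (a higher number here means a weaker inhibitor, a lower number a stronger inhibitor), compound 1 gives 100000 nM. In this assay compound 2 gives 75000 nM. The change between them is amino in place of nitro on an aromatic carbon, and the step is a 1.3-fold lower number from compound 1 to compound 2 (0.12 log units; within the scatter). In this assay, among the compounds with values here, compound 3 gives 2500 nM, the lowest of the three numbers measured so far; compound 2 stands nearest to it and compound 1 furthest.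

The change from compound 3 to compound 4 is amino in place of nitro on an aromatic carbon. The surroundings of the place are described in the same words for both pairs, so this is the same change, made two times in all among the compounds shown.

For compound 4 the expected step in this assay is a 1.3-fold lower number from compound 3 to compound 4 (0.10 log units; within the scatter). That expectation rests on a 1.3-fold lower number from compound 1 to compound 2 (0.12 log units; within the scatter), a step that stayed within the scatter, so no clear shift is expected on the second core either. Compound 4 is therefore expected to give about 2000 nM in this assay, most likely falling between 700 nM and 6000 nM.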

Compound 4, half-maximal inhibitory concentration: 5 nM
Estimate against measurement, compound 4: 400-fold (2.60 log units) above, and the stated range ends above it.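

The exchange of nitro for amino does not carry over from one core to the other in this assay: the same change on two cores in this assay, a 1.3-fold lower number (0.12 log units; within the scatter) from compound 1 to compound 2 and a 500-fold lower number (2.70 log units; beyond the scatter) from compound 3 to compound 4, 380-fold (2.57 log units) apart, beyond the scatter of two such steps

On the core of compound 3, the exchange gives a 500-fold lower number from compound 3 to compound 4 (2.70 log units; beyond the scatter), so the near-absence of a shift on the core of compound 1 is no guide to the size of the step on the core of compound 3. These two pairs show that the outcome of this exchange depends on the core, but they do not show which part of the core is responsible or why the two cores differ, and two pairs in a single assay support no general rule for the series.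

The compounds shown leave open which of the features separating the two cores decides whether the amino group brings a large step, and whether the same step would appear in cells other than those of this assay. They also leave open what a hydroxyl, a methylamino or an acetylamino group would give at the same place on the core of compound 3.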